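The source may hold more compounds than are shown below. What is called first, only, known or untested is meant among the compounds shown, and "the series" means these compounds.

Compound 1 `CC(C)OC(=O)N1CCC(Oc2cccc3c2CCN3c2ccc(S(C)(=O)=O)cc2)CC1` and compound 2 `CC(C)(C)OC(=O)N1CCC(Oc2cccc3c2CCN3c2ccc(S(C)(=O)=O)cc2)CC1` share one core, while compound 3 `CCCOC(=O)N1CCC(Oc2ncnc3c2CCN3c2ccc(S(C)(=O)=O)cc2F)CC1` and compound 4 `CCCCOC(=O)N1CCC(Oc2ncnc3c2CCN3c2ccc(S(C)(=O)=O)cc2F)CC1` share another; the difference between the two cores is not broken down here. All of them are judged in a functional assay on CHO-K1 cells with Glucose-dependent insulinotropic receptor (Homo sapiens) as the target, read by a luciferase reporter, with a stated time of 5 h; a lower number here means a smaller maximal response, a higher number a larger maximal response. In this assay compound 1 gives 70%, and compound 2 gives 92%. The change between them is methyl in place of hydrogen on a saturated chain carbon bound to an oxygen next to a carbonyl group and two saturated chain carbons, and it made a step of a number 22 percentage points higher from compound 1 to compound 2 (beyond the scatter). Compound 3 gives 111% in this assay, the highest of the three numbers, and its distance to compound 2 as well as to compound 1 lies beyond the usual scatter.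

Compound 4 has not yet been measured. It differs from compound 3 by methyl in place of hydrogen on a saturated chain carbon, three bonds along the chain from an oxygen next to a carbonyl group. This is the same kind of change as that from compound 1 to compound 2, but not the same: there the entering methyl sat on a saturated chain carbon bound to an oxygen next to a carbonyl group and two saturated chain carbons, whereas here it sits three bonds along the chain from an oxygen next to a carbonyl group. One measured step, made at a different place and on a different core, is a thin basis for a forecast. I expect the step from compound 3 to compound 4 in this assay to be about a number 1 percentage points lower from compound 3 to compound 4 (within the scatter), because compound 3 already reaches 111% and a response above the reference leaves little room to climb. For compound 4 I estimate 110% in this assay. The expected range for compound 4 runs from 90% to 130%.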

Compound 4, largest response reached (reported as percent of maximum), in percent of the reference or control that the assay uses: 131%
Compound 4: middle estimate off by 21 percentage points, on the low side, and the stated range ends below it.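

In this assay, turning propyl into butyl made a step of a number 20 percentage points higher from compound 3 to compound 4 (beyond the scatter), and set beside the earlier methyl step on the other core, its size is matched: the same change on two cores in this assay, a number 22 percentage points higher (beyond the scatter) from compound 1 to compound 2 and a number 20 percentage points higher (beyond the scatter) from compound 3 to compound 4, 2 percentage points apart, within the scatter of two such steps

Within these four compounds, then, adding one methyl to the chain on the oxygen raised the maximal response by a similar amount on both cores, even though the methyl enters at a different place in each pair. For the compounds shown here, this does not establish a general rule, since it rests on only two pairs, and a match between two steps cannot show that the same thing lies behind both or that a third core would respond in the same way.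

The compounds shown leave open whether a longer chain such as pentyl, or a ring such as cyclopropyl, on that oxygen would raise the response further on the core of compound 4 or whether the rise would level off. They also leave open how propyl and butyl chains would behave on the core of compound 1, which would compare the two cores more directly.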